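Swapping Trifluorophenyl for Trifluoromethylphenyl on a Shared Core

The source may report more compounds than this note shows. Statements on the series, on what has been measured and on what is new or still open speak of the compounds shown alone.

Compound 1 `OC[C@H]1O[C@@H](n2cnc3c(NCc4ccccc4Cl)ncnc32)[C@H](O)[C@@H]1O` in a functional assay on HOS cells (Homo sapiens) for antiproliferative activity, with a stated time of 72 h (on this read-out higher numbers stand for weaker inhibition and lower numbers for stronger inhibition), gives only a limit, > 166000 nM.
Compound 2 `COc1ccc(CNc2ncnc3c2ncn3[C@@H]2O[C@H](CO)[C@@H](O)[C@H]2O)c(OC)c1` in this assay gives only a limit, > 166000 nM.
Compound 3 `OC[C@H]1O[C@@H](n2cnc3c(NCc4ccc(F)c(F)c4F)ncnc32)[C@H](O)[C@@H]1O` in this assay gives only a limit, > 166000 nM.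

Compound 3 therefore stands at the same point as both of its neighbours: all three values sit at the limit of > 166000 nM in this assay, at which 3 of the 3 values shown sit. The steps between them, a step that the two limits leave unreadable from compound 1 to compound 2, a step that the two limits leave unreadable from compound 1 to compound 3 and a step that the two limits leave unreadable from compound 2 to compound 3, cannot be read in size because the limit of > 166000 nM in this assay, at which 3 of the 3 values shown sit, caps every value.

Compound 4 `OC[C@H]1O[C@@H](n2cnc3c(NCc4cccc(C(F)(F)F)c4)ncnc32)[C@H](O)[C@@H]1O` differs from compound 3 in one place: 3-(trifluoromethyl)phenyl in place of 2,3,4-trifluorophenyl on a saturated chain carbon bound to a nitrogen on an aromatic ring. Among the measured compounds shown here, no measured step here has a readable size, so none shows how this change might move the read-out. Compound 4 is expected to give 200000 nM, between 80000 nM and 500000 nM, most likely again as a limit. The expected step is a step that the limit leaves unreadable from compound 3 to compound 4.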

Compound 4, half-maximal inhibitory concentration: > 166000 nM
Compound 4 gave a limit, no number; the forecaster's own chance of this, stated with the estimate: 85%; the middle value lies beyond the limit too.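

No step between compound 4 and compound 1, compound 2 or compound 3 can be read in this assay, because all four compounds give only a limit: the limit of > 166000 nM in this assay, at which 4 of the 4 values shown sit.

The compounds shown leave open whether changing the group on the shared core moves the read-out at all.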